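The compounds below may be only part of what the source reports. "The series", "measured", "known", "first", "only" and "open" are said of these compounds alone.

Measured so far:
- compound 1, `CCCCNC(=O)Oc1cccc(-n2ccc(C(N)=O)c2)c1`, 60 nM
- compound 2, `Cc1cc(C(N)=O)c(-c2cccc(OC(=O)NCCCCCCc3ccccc3)c2)o1`, 0.49 nM

In an assay (brain) for inhibition of Fatty-acid amide hydrolase 1 (Mus musculus), with stated times of 20 min and 15 min (on this read-out higher numbers stand for weaker inhibition and lower numbers for stronger inhibition), compound 1 gives 60 nM, the higher of the two numbers recorded. For the measured compounds named here, compound 2 gives 0.49 nM in this assay, and the gap between the two values is well beyond the scatter, with the number for compound 2 the lower of the pair; the two compounds differ in more than one place, so no single step connects them.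

Compound 3, `NC(=O)c1ccn(-c2cccc(OC(=O)NCCOCCOc3ccccc3)c2)c1`, differs from compound 1 by 2-phenoxyethoxy in place of ethyl on a saturated chain carbon, two bonds along the chain from an amide-type nitrogen. Going by the values given here, no measured pair shows this particular change on its own, so the size of the step has to be judged from the few numbers in hand. Among the compounds with values here, the one measured compound whose carbamate chain also ends in a phenyl ring, compound 2, gives 0.49 nM in this assay, though it differs from compound 1 elsewhere as well. On that basis the step from compound 1 to compound 3 is expected to lower the number, a 12-fold lower number from compound 1 to compound 3 (1.08 log units; beyond the scatter), a move beyond the scatter toward stronger inhibition. For compound 3 the estimated value in this assay is 5 nM, with a likely range from 1 nM to 25 nM.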

Compound 3, inhibition constant: 23 nM
Compound 3: middle estimate off by 4.6-fold (0.66 log units), on the low side; the measured number falls inside the stated range.
By their numbers in this assay, from the lowest: compound 2; then compound 3; then compound 1.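

For the compounds shown here, compound 3 gives the first direct reading at this position: 2-phenoxyethoxy in place of ethyl on a saturated chain carbon, two bonds along the chain from an amide-type nitrogen, produces a 2.6-fold lower number from compound 1 to compound 3 (0.42 log units; beyond the scatter) in this assay. The shared core therefore keeps its inhibition when this short chain end gives way to a far larger group that brings in an aromatic ring and ether oxygens, and the number even moves toward stronger inhibition. That move is only modest for so large a change in the group, and nothing measured here accounts for its size.

The compounds shown leave open which part of 2-phenoxyethoxy carries the step, the phenyl ring or the chain oxygens, since both enter together in this single change. They also leave open how the core of compound 1 would read with an all-carbon chain ending in a phenyl ring, with a longer ether chain, or with an amine at the end of the chain.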